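Aryl amine variation on the shared core: three measured, one pending

The compounds below may be only part of what the source reports. "The series", "measured", "known", "first", "only" and "open" are said of these compounds alone.

Measured compounds:
- compound 1 `Cc1cc(=O)oc2cc(OCc3nc(N)nc(Nc4cccc(Cl)c4)n3)ccc12`: 1110 nM in an assay on COS-7 cells for agonist activity at Free fatty acid receptor 1 (Homo sapiens), read by scintillation counting and inositol phosphate accumulation, with a stated time of 90 min; a lower number here means that less compound is needed, a higher number that more compound is needed for the effect
- compound 2 `Cc1cc(=O)oc2cc(OCc3nc(N)nc(Nc4ccc(C5CC5)cc4)n3)ccc12`: 700 nM in this assay
- compound 3 `Cc1cc(=O)oc2cc(OCc3nc(N)nc(Nc4ccc(Cl)c(Cl)c4)n3)ccc12`: 780 nM in this assay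

Compound 3 holds the second highest of the three numbers; its nearest neighbour is compound 2, with a 1.1-fold higher number from compound 2 to compound 3 (0.05 log units; within the scatter), and its furthest is compound 1, with a 1.4-fold lower number from compound 1 to compound 3 (0.15 log units; within the scatter). All three compounds sit within the scatter of one another, so no order among them can be claimed.

Compound 4 `Cc1c(Cl)cc(Nc2nc(N)nc(COc3ccc4c(C)cc(=O)oc4c3)n2)cc1Cl` is not yet measured. It differs from compound 3 only at the aryl group on the nitrogen: 3,5-dichloro-4-methylphenyl in place of 3,4-dichlorophenyl on a nitrogen on an aromatic ring.

Among the compounds with values here, the steps that bear on this change all alter the same aryl group or a substituent on it: a 1.6-fold lower number from compound 1 to compound 2 (0.20 log units; within the scatter), a 1.4-fold lower number from compound 1 to compound 3 (0.15 log units; within the scatter) and a 1.1-fold higher number from compound 2 to compound 3 (0.05 log units; within the scatter). Each of them stayed within the scatter. On that basis no step beyond the scatter is expected for compound 4 in this assay; the estimated step is a 1.0-fold higher number from compound 3 to compound 4 (0.01 log units; within the scatter). Compound 4 is therefore expected to give about 800 nM, with a plausible range from 400 nM to 1600 nM.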

Compound 4, half-maximal effective concentration: 600 nM
The estimate for compound 4 lay 1.3-fold (0.12 log units) above the measured number, and the stated range covers the measured number.
By their numbers in this assay, from the lowest: compounds 4, 2, 3 and 1 (each within the scatter of the next).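

In this assay the aryl group on the nitrogen also accepts 3,5-dichloro-4-methylphenyl, and each step to it stays within the scatter (a 1.3-fold lower number from compound 3 to compound 4 (0.11 log units; within the scatter)) (a 1.2-fold lower number from compound 2 to compound 4 (0.07 log units; within the scatter)) (a 1.9-fold lower number from compound 1 to compound 4 (0.27 log units; within the scatter)). This position has now carried four different aryl groups, including one with substituents at the 3, 4 and 5 positions, and no order among the four compounds can be claimed. No data are available that would explain these small steps.

The compounds shown leave open whether an amine, a carboxylic acid or a methoxy group on this aryl ring would give a step beyond the scatter. They also leave open whether a cyclohexyl group in place of the aryl ring on this nitrogen would do so.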